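This account rests on a few compounds, and the source may have more. Where it says the series, first, only, none or still open, it means among the compounds named here.

Of the compounds shown here, three have so far been tested in a functional assay on the whole organism for agonist activity, with Mus musculus as the target; on this read-out higher numbers stand for an effect only at larger amounts of compound and lower numbers for an effect already at smaller amounts. Compound 2 `CC(=O)N(C)CC#CCn1ccnc1` gives 1.4 mg/kg in this assay. Compound 1 `CC(=O)N(C)C(C)C#CCn1ccnc1` differs from it by methyl in place of hydrogen on a saturated chain carbon bound to an amide-type nitrogen and a triple-bonded carbon, and in this assay compound 1 gives 3 mg/kg. That single change produced a step of a 2.1-fold higher number from compound 2 to compound 1 (0.33 log units; beyond the scatter). Compound 3 `COC(=O)N(C)CC#CCN1CCCC1` is built on a different core; the difference between the two cores is not broken down here. In this assay compound 3 gives 3 mg/kg, which stands level with compound 1 at the digits shown and within the usual scatter of it, while its gap to compound 2 lies beyond that scatter.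

Compound 4 `COC(=O)N(C)C(C)C#CCN1CCCC1` has not yet been measured. It is made from compound 3 by methyl in place of hydrogen on a saturated chain carbon bound to an amide-type nitrogen and a triple-bonded carbon. For the measured compounds named here, this is the same change as the one from compound 2 to compound 1, and the place it sits is described in the same words for both pairs, so the earlier step is the only guide to what it will do on the new core. On that one example, which gave a 2.1-fold higher number from compound 2 to compound 1 (0.33 log units; beyond the scatter), a step of about the same size is expected, a 2.0-fold higher number from compound 3 to compound 4 (0.30 log units; within the scatter). The expectation rests on a single pair, so the range is kept wide. Compound 4 is therefore estimated at 6 mg/kg in this assay, with a likely span from 3 mg/kg to 12 mg/kg.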

Compound 4, dose for half-maximal effect: 20.9 mg/kg
For compound 4 the middle estimate is 3.5-fold (0.54 log units) below the measured one, and the stated range ends below it.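

In this assay, methyl in place of hydrogen on this saturated chain carbon gave a 7.0-fold higher number from compound 3 to compound 4 (0.84 log units; beyond the scatter), so the number rose on the new core just as it had on the earlier one, and the direction of the change carried over. The size of the change did not carry over, and the two steps cannot be treated as one shared effect of the methyl: the same change on two cores in this assay, a 2.1-fold higher number (0.33 log units; beyond the scatter) from compound 2 to compound 1 and a 7.0-fold higher number (0.84 log units; beyond the scatter) from compound 3 to compound 4, 3.3-fold (0.51 log units) apart, beyond the scatter of two such steps These two pairs show that the same small change can cost much more on one core than on the other, but they do not show which part of the cores accounts for the gap, why the methyl acts as it does, or what the step would be on any third core.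

The compounds shown leave open what an ethyl group or a longer chain would do in place of the methyl at this carbon, and whether the number would keep rising on either core. They also leave open which end of the molecule sets the size of the step, a question that could be tested by a pair of compounds combining one end of compound 2 with the other end of compound 3, with and without the methyl.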